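Arylpiperazine phthalazinone series: alpha-1 displacement notes

The source may report more compounds than this note shows. Statements on the series, on what has been measured and on what is new or still open speak of the compounds shown alone.

Measured so far:
- compound 1 `Cc1ccc(-c2nn(CCN3CCN(c4ccccc4)CC3)c(=O)c3ccccc23)cc1`: 25.3 nM
- compound 2 `CCOc1ccccc1N1CCN(CCCCn2nc(-c3ccc(C)cc3)c3ccccc3c2=O)CC1`: 2.23 nM

In an assay on Cerebral cortex for displacement of a labelled ligand from Adrenergic receptor alpha-1 (Rattus norvegicus) (on this read-out higher numbers stand for weaker inhibition and lower numbers for stronger inhibition), compound 1 gives 25.3 nM, and compound 2 gives 2.23 nM. Compound 2 stands at the lower of the two numbers, with compound 1 the nearest neighbour at a clearly higher value, a gap beyond the usual scatter. Among the measured compounds shown here, the two compounds differ in more than one place, so no single step between them is defined; their two values are simply compared as they stand.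

Compound 3 `Cc1ccc(-c2nn(CCCCN3CCN(CC4COc5ccccc5O4)CC3)c(=O)c3ccccc23)cc1` is the next candidate. Relative to compound 2 it carries (2,3-dihydro-1,4-benzodioxin-2-yl)methyl in place of 2-ethoxyphenyl on an amine nitrogen in a ring. For the measured compounds named here, no measured pair covers this change, so the step is an expectation only. The four-carbon linker and the shared core of compound 2 are kept, and the piperazine nitrogen still bears an aromatic-containing group, so the expected outcome is a modest shift upward or none beyond the scatter. For compound 3 the estimate in this assay is 5 nM, in the range 1.5 nM to 20 nM. The expected step is a 2.2-fold higher number from compound 2 to compound 3 (0.35 log units; beyond the scatter).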

Compound 3, inhibition constant: 180 nM
Beside the measured number, compound 3's estimate is 36-fold (1.56 log units) below it, outside the stated range (above it).
By their numbers in this assay, from the lowest: compound 2; then compound 1; then compound 3.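

Among the compounds shown here, on the amine nitrogen in the ring, with the rest of the structure held constant, (2,3-dihydro-1,4-benzodioxin-2-yl)methyl in place of 2-ethoxyphenyl gives in this assay an 81-fold higher number from compound 2 to compound 3 (1.91 log units; beyond the scatter), the first single-place step, which shows that the group at this position alone can greatly weaken inhibition. Both groups contain a six-membered aromatic ring of carbon only, so the presence of such a ring in the substituent is not enough to keep the number of compound 2 in this pair. No supporting measurement bears on why this change has so large an effect.

The change alters several features at once, including the added non-aromatic ring with its 2 hetero atoms and the way the aromatic ring is attached, so this pair does not show which feature matters. From the compounds shown here alone, a plain benzyl group or an unsubstituted phenyl group on the same nitrogen, each set on the four-carbon linker and shared core of compound 2, would help separate these features, and the contribution of the linker itself also remains open.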